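The source may hold more compounds than are shown below. What is called first, only, known or untested is meant among the compounds shown, and "the series" means these compounds.

Compound 1 `C=C1CCCC(C)(C)C1CC[C@]1(C)CC[C@@H]([C@@H](C)C(=O)O)OO1` is an acid on the shared core. In a functional assay on RPMI8266 cells (Homo sapiens) for inhibition (on this read-out higher numbers stand for weaker inhibition of growth and lower numbers for stronger inhibition of growth), compound 1 gives only a limit, > 10000 nM, so its standing rests on the limit of > 10000 nM in this assay, at which 1 of the 2 values shown sits, rather than on a number. The methyl ester compound 2 `C=C1CCCC(C)(C)C1CC[C@]1(C)CC[C@H]([C@@H](C)C(=O)OC)OO1` gives 4040 nM in this assay. Compound 3 `C=C1CCCC(C)(C)C1CC[C@@]1(C)CC[C@H]([C@@H](C)C(=O)O)OO1` keeps every atom of compound 1 and differs in configuration alone: the two compounds have the same atoms and bonds; at least one stereo element is drawn with a configuration in one of them and without one in the other: 2 of 4 stereo elements differ; a stereocentre at a saturated ring carbon is drawn R in compound 1 and S in compound 3; a stereocentre at a saturated ring carbon is drawn S in compound 1 and R in compound 3. Among the measured compounds shown here, no measured pair maps a change of this kind. The step from compound 1 to compound 3 is expected as an at least 1.1-fold lower number from compound 1 to compound 3 (0.04 log units; that floor lies within the scatter), with no firm direction. Compound 3 is estimated at 9000 nM, within 2500 nM to 30000 nM.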

Compound 3, concentration for 50% growth inhibition: 3910 nM
Estimate against measurement, compound 3: 2.3-fold (0.36 log units) above; the range from low to high includes it.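

In this assay, configuration alone separates the two acids on the shared core: an at least 2.5-fold lower number from compound 1 to compound 3 (0.40 log units; beyond the scatter) with atoms and bonds unchanged. Among the compounds shown here, this is the first pair to map a change of this kind, and its size is only a bound, as compound 1 stands at a limit: the limit of > 10000 nM in this assay, at which 1 of the 3 values shown sits. Reading the step as an effect of configuration carries a caveat: the fact that one of compounds 1 and 3 is drawn with a defined configuration and the other without, at the place where they differ.

Which of the two stereocentres carries the step remains open. So does how a primary amide in place of the carboxylic acid would stand in either configuration.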